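Replacing piperidin-4-yl on an antiproliferative lead

The source may hold more compounds than are shown below. What is called first, only, known or untested is meant among the compounds shown, and "the series" means these compounds.

- Compound 1 `c1ccc(-c2noc(-c3ccncc3)n2)cc1`: 710000 nM
- Compound 2 `COc1ccc(-c2noc(C3CCNCC3)n2)cc1OC1CCCC1`: 10 nM

In a functional assay on LNCaP cells (Homo sapiens) for antiproliferative activity, read by MTT assay, with a stated time of 24 h (on this read-out lower numbers stand for stronger inhibition and higher numbers for weaker inhibition), compound 2 at 10 nM has the lower of the two numbers, and its gap to compound 1 lies beyond the scatter. Compound 3 `COc1ccc(-c2noc(-c3ccc(Cl)cc3)n2)cc1OC1CCCC1` has 4-chlorophenyl in place of piperidin-4-yl on an aromatic carbon. Among the measured compounds shown here, no measured step shows this change alone. Compound 1 also lacks piperidin-4-yl and gives 710000 nM, so weaker inhibition is expected, though the two compounds differ elsewhere too. The expected rise, beyond the scatter, is a 100-fold higher number from compound 2 to compound 3 (2.00 log units; beyond the scatter). The estimate for compound 3 is 1000 nM, with a range of 30 nM to 50000 nM.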

Compound 3, half-maximal inhibitory concentration: 20800 nM
Compound 3: middle estimate off by 21-fold (1.32 log units), on the low side, within the range that was stated.
By their numbers in this assay, from the lowest: compound 2; then compound 3; then compound 1.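

With the rest of compound 2 unchanged, putting 4-chlorophenyl in place of piperidin-4-yl gives, in this assay, a 2100-fold higher number from compound 2 to compound 3 (3.32 log units; beyond the scatter), so the number depends strongly on the group at this position. This single change removes the ring nitrogen and also replaces a non-aromatic ring with an aromatic one. Nothing available explains the loss of inhibition.

Which of these two differences matters remains open. A cyclohexyl group or a 4-aminophenyl group at this position could help separate them.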